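A Fluorine for a Methyl on a Fused Core

The source may hold more compounds than are shown below. What is called first, only, known or untested is meant among the compounds shown, and "the series" means these compounds.

Of the compounds shown here, three have been measured, all in a functional assay on PC-3 cells (Homo sapiens) for cytotoxicity, read by WST assay, with a stated time of 72 h; a lower number here means a stronger inhibitor, a higher number a weaker inhibitor. Compound 1 `Cc1cc(C)c2c(c1)C(c1ccc(O)cc1)(C1CCCCCC1)C(=O)N2` was the first. In this assay compound 1 gives > 1000 nM, which is a limit of the assay and not a number. Compound 2 `Cc1cc(F)cc2c1NC(=O)C2(c1ccc(O)cc1)C1CCCCCC1` differs from compound 1 by fluoro in place of methyl on an aromatic carbon. In this assay compound 2 gives > 1000 nM, again a limit. The step that the two limits leave unreadable from compound 1 to compound 2 therefore cannot be read as a size. Compound 3 `Cc1ccc2c(c1C)NC(=O)C2(c1ccc(O)cc1)C1CCCCCC1` has the same atoms as compound 1, joined differently; the difference between the two cores is not broken down here. In this assay compound 3 gives > 1000 nM, also a limit. All three values rest on (the limit of > 1000 nM in this assay, at which 3 of the 3 values shown sit).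

Compound 4 `Cc1c(F)ccc2c1NC(=O)C2(c1ccc(O)cc1)C1CCCCCC1` has not yet been measured. It differs from compound 3 by fluoro in place of methyl on an aromatic carbon. Going by the values given here, this is the same kind of change as the one between compound 1 and compound 2, but the surroundings are not identical: in compound 4 the fluoro stands ortho to a methyl group, while in compound 2 it stands meta to a methyl group.

The earlier step that the two limits leave unreadable from compound 1 to compound 2 stayed within the limit. The step from compound 3 to compound 4 is expected to be a step that the limit leaves unreadable from compound 3 to compound 4, an expectation that rests on (the limit of > 1000 nM in this assay, at which 3 of the 3 values shown sit). Compound 4 is expected to give roughly 3000 nM, with a likely range from 1000 nM to 10000 nM, and most probably the assay will again report only a limit.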

Compound 4, half-maximal inhibitory concentration: 30 nM
The estimate for compound 4 lay 100-fold (2.00 log units) above the measured number; the measured number lies below the stated range.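

In this assay, fluoro in place of methyl on an aromatic carbon gives an at least 33-fold lower number from compound 3 to compound 4 (1.52 log units; beyond the scatter), so on this core, with the fluoro ortho to a methyl group, the change has a large effect. The same kind of change on the core of compound 1 leads to compound 2, and compound 2 gives > 1000 nM, which is a limit of the assay and not a number. This shows that the change does not always bring a readable value when carried from one core to another, but it does not show how the two steps differ in size, since the earlier step cannot be read, and a single readable pair sets no rule for the series, because most values sit at one limit: the limit of > 1000 nM in this assay, at which 3 of the 4 values shown sit.

The compounds shown leave open whether the large step belongs to fluoro itself or whether another group on the same aromatic carbon, such as chloro, a nitrile or a methoxy group, would give a similar number. They also leave open how much the hydroxyl group on the phenyl ring contributes to the value of compound 4, for example whether an amine or a carboxylic acid in its place would keep it.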